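Removing a Chlorine from a Weakly Active Enone

This account rests on a few compounds, and the source may have more. Where it says the series, first, only, none or still open, it means among the compounds named here.

Two measured compounds share one core: compound 1 `Cc1nc(Nc2ccc(Cl)cc2)sc1C(=O)/C=C/c1ccccc1` and compound 2 `Cc1ccccc1Nc1nc(C)c(C(=O)/C=C/c2ccc(Cl)cc2)s1`. Both were tested in a functional assay on Bel-7402 cells (Homo sapiens) for cytotoxicity, read by MTT assay; on this read-out higher numbers stand for weaker inhibition and lower numbers for stronger inhibition. In this assay compound 1 gives > 25000 nM, which is a limit of the assay and not a number. Compound 2 gives > 25000 nM in this assay, again a limit of the assay rather than a measured number. Compound 2 therefore stands where every value shown stands, at the limit of > 25000 nM in this assay, at which 2 of the 2 values shown sit, so there is no place within the shown data where it could be called stronger or weaker than anything else.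

Compound 3 `Cc1ccccc1Nc1nc(C)c(C(=O)/C=C/c2ccccc2)s1` is not yet measured. It differs from compound 2 in one place: hydrogen in place of chloro on an aromatic carbon, which read one bond further out is 4-chlorophenyl becoming phenyl. Among the measured compounds shown here, no step between two measured compounds is available, because compounds 1 and 2 differ in more than one place and both sit only at a limit.

Given that compound 2 shows only a limit, the step from compound 2 to compound 3 is expected to be none beyond the scatter, a step that the limit leaves unreadable from compound 2 to compound 3. Compound 3 is expected to give about 40000 nM in this assay, with a range from 15000 nM to 150000 nM, and most likely only a limit will be reported.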

Compound 3, half-maximal inhibitory concentration: > 25000 nM
Compound 3 gave a limit, no number; the forecaster's own chance of this, stated with the estimate: 85%; the middle value does not contradict the limit.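

In this assay compound 3 gives > 25000 nM, which is a limit of the assay and not a number. No step to compound 3 from compound 1 or compound 2 can therefore be read: the limit of > 25000 nM in this assay, at which 3 of the 3 values shown sit.

The compounds shown leave open whether hydrogen in place of chloro changes cytotoxicity at all, and which change to the shared core would give a measurable value.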